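The source may hold more compounds than are shown below. What is called first, only, known or untested is meant among the compounds shown, and "the series" means these compounds.

Series notes. In a functional assay on MV4-11 cells (Homo sapiens) for antiproliferative activity, read by CCK-8 assay, with a stated time of 72 h (on this read-out higher numbers stand for weaker inhibition and lower numbers for stronger inhibition), compound 1 `Cn1cc(-c2cc(C(C)(C)O)ccc2OC2CC2)c2cc(C(=O)NCc3ccc(C(=O)Nc4ccccc4N)cc3)[nH]c2c1=O` gives 40 nM, compound 2 `Cn1cc(-c2ccccc2Oc2ccccc2)c2cc(C(=O)NCc3ccc(C(=O)Nc4ccccc4N)cc3)[nH]c2c1=O` gives 80 nM and compound 3 `Cc1ccccc1-c1cn(C)c(=O)c2[nH]c(C(=O)NCc3ccc(C(=O)Nc4ccccc4N)cc3)cc12` gives 310 nM; compound 3 thus holds the highest of the three numbers, with compound 2 nearest and compound 1 furthest. For the measured compounds named here, the single one-point step on record is a 3.9-fold higher number from compound 2 to compound 3 (0.59 log units; beyond the scatter). Compound 4 `COc1ccc(C(C)(C)O)cc1-c1cn(C)c(=O)c2[nH]c(C(=O)NCc3ccc(C(=O)Nc4ccccc4N)cc3)cc12` differs from compound 3 by 5-(1-hydroxy-1-methylethyl)-2-methoxyphenyl in place of 2-methylphenyl on an aromatic carbon. Going by the values given here, no measured step matches this change directly; the move from compound 2 to compound 3 shows that a larger group at this position went with a lower number, and compound 1, which also carries the 1-hydroxy-1-methylethyl group, gives the lowest number in this assay. For compound 4 a lower number is therefore expected, the expected step being a 5.2-fold lower number from compound 3 to compound 4 (0.71 log units; beyond the scatter). In this assay compound 4 is estimated at 60 nM, range 25 nM to 150 nM.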

Compound 4, half-maximal inhibitory concentration: 420 nM
Beside the measured number, compound 4's estimate is 7.0-fold (0.85 log units) below it; measured number outside the range, above it.
By their numbers in this assay, from the lowest: compounds 1 and 2 (each within the scatter of the next); then compounds 3 and 4 (each within the scatter of the next).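

In this assay, the 5-(1-hydroxy-1-methylethyl)-2-methoxyphenyl group in place of 2-methylphenyl gives a 1.4-fold higher number from compound 3 to compound 4 (0.13 log units; within the scatter), so the larger group does not set compound 4 apart from compound 3. With the 1-hydroxy-1-methylethyl group present in both, methyl in place of cyclopropyl on the oxygen gives an 11-fold higher number from compound 1 to compound 4 (1.02 log units; beyond the scatter), so the group on that oxygen matters and the 1-hydroxy-1-methylethyl group alone does not give a low number. Nothing on record explains either step. Still open, as far as these compounds go, is how ethyl or cyclobutyl on that oxygen would read, and whether an amine in place of the 1-hydroxy-1-methylethyl group would change the number with cyclopropyl kept on the oxygen.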